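Shrinking the Sulfonyl Substituent to a Methyl Group

This account rests on a few compounds, and the source may have more. Where it says the series, first, only, none or still open, it means among the compounds named here.

Compound 2 `Cc1cccc(S(=O)(=O)Nc2ccc(-c3nc4ccccc4o3)cc2)c1` was tested in an assay on isolated protein for inhibition of malate dehydrogenase, mitochondrial (Sus scrofa), with stated times of 45 min and 30 min; a higher number here means a weaker inhibitor, a lower number a stronger inhibitor. In this assay compound 2 gives only a limit, > 63000 nM. Compound 1 `O=S(=O)(Nc1ccc(-c2nc3ccccc3o2)cc1)c1ccccc1C(F)(F)F` likewise gives only a limit, > 63000 nM. Compound 3 `O=S(=O)(Nc1ccc(-c2nc3ccccc3o2)cc1)c1cccc(C(F)(F)F)c1` also gives only a limit, > 63000 nM. The step from compound 2 to compound 3 is a step that the two limits leave unreadable from compound 2 to compound 3, trifluoromethyl in place of methyl on an aromatic carbon. All values shown share (the limit of > 63000 nM in this assay, at which 3 of the 3 values shown sit). Compound 4 `CS(=O)(=O)Nc1ccc(-c2nc3ccccc3o2)cc1` differs from compound 2 by methyl in place of 3-methylphenyl on a sulfonyl sulfur. Among the compounds with values here, no measured step bears directly on this change, and the one measured step is unreadable, so no size can be drawn from it. Because every value sits at the limit of > 63000 nM in this assay, at which 3 of the 3 values shown sit, compound 4 is expected to remain at the limit too. The step from compound 2 to compound 4 is estimated as a step that the limit leaves unreadable from compound 2 to compound 4. Compound 4 is estimated at 100000 nM, within 30000 nM to 400000 nM.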

Compound 4, half-maximal inhibitory concentration: > 63000 nM
Compound 4: no number, only a limit; the forecaster's own chance of this, stated with the estimate: 85%; the middle value is on the limit's open side.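

The step from compound 2 to compound 4 cannot be read, since each gives only a limit in this assay. The compounds shown leave open whether any sulfonyl substituent on the shared core gives a measurable value, as all remain at one ceiling: the limit of > 63000 nM in this assay, at which 4 of the 4 values shown sit.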